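The source may report more compounds than this note shows. Statements on the series, on what has been measured and on what is new or still open speak of the compounds shown alone.

Measured so far in a functional assay on PBMC cells (Homo sapiens) for inhibition; on this read-out lower numbers stand for stronger inhibition and higher numbers for weaker inhibition:
compound 1 `NC(=O)CC[C@H](N)C(=O)NS(=O)(=O)OC[C@H]1O[C@@H](n2cnc3c(N)ncnc32)[C@H](O)[C@@H]1O` — 800 nM
compound 2 `CC(C)C[C@H](N)C(=O)NS(=O)(=O)OC[C@H]1O[C@@H](n2cnc3c(N)ncnc32)[C@H](O)[C@@H]1O` — 1100 nM
compound 3 `Nc1ncnc2c1ncn2[C@@H]1O[C@H](COS(=O)(=O)NC(=O)[C@@H]2CCCN2)[C@@H](O)[C@H]1O` — 700 nM

All three share the same core and differ only in the group on the carbonyl carbon. The steps among them are small: a 1.4-fold higher number from compound 1 to compound 2 (0.14 log units; within the scatter), a 1.1-fold lower number from compound 1 to compound 3 (0.06 log units; within the scatter), a 1.6-fold lower number from compound 2 to compound 3 (0.20 log units; within the scatter). Compound 3 thus stands apart from the other two only by steps within the scatter, and no ranking among the three can be read from these numbers.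

Compound 4 `CCC[C@H](N)C(=O)NS(=O)(=O)OC[C@H]1O[C@@H](n2cnc3c(N)ncnc32)[C@H](O)[C@@H]1O` is not yet measured. Its change from compound 3 is 1-aminobutyl in place of pyrrolidin-2-yl on a carbonyl carbon. Two kinds of measured step bear on it. The exchange of one open side chain for another, compound 1 to compound 2, gave a 1.4-fold higher number from compound 1 to compound 2 (0.14 log units; within the scatter). The exchange of an open chain for the pyrrolidin-2-yl ring, compound 1 to compound 3 and compound 2 to compound 3, gave a 1.1-fold lower number from compound 1 to compound 3 (0.06 log units; within the scatter) and a 1.6-fold lower number from compound 2 to compound 3 (0.20 log units; within the scatter). Nothing in this set moved beyond the scatter, so for compound 4 no step beyond the scatter is expected in this assay, in either direction: the expected step is a 1.1-fold higher number from compound 3 to compound 4 (0.06 log units; within the scatter). Compound 4 is therefore estimated at 800 nM, with a range of 400 nM to 1600 nM.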

Compound 4, half-maximal inhibitory concentration: 4700 nM
Beside the measured number, compound 4's estimate is 5.9-fold (0.77 log units) below it; the whole stated range lies below it.
By their numbers in this assay, from the lowest: compounds 3, 1 and 2 (each within the scatter of the next); then compound 4.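

In this assay this position turns out to be sensitive to the side chain. Within the data shown here, the first step beyond the scatter (a 6.7-fold higher number from compound 3 to compound 4 (0.83 log units; beyond the scatter)) comes with 1-aminobutyl in place of pyrrolidin-2-yl, two groups with the same counts of heavy atoms, donors and acceptors, which differ in that one has a ring and the other has none. The absence of a ring does not by itself set the higher number, since compound 1 and compound 2 also carry open chains and stand within the scatter of compound 3, whereas the small edits that separate them from compound 4 both count: hydrogen in place of methyl on a saturated chain carbon bound to two saturated chain carbons (a 4.3-fold higher number from compound 2 to compound 4 (0.63 log units; beyond the scatter)) and methyl in place of carbamoyl (a 5.9-fold higher number from compound 1 to compound 4 (0.77 log units; beyond the scatter)). No measurement at hand gives a reason for these steps.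

Open, on these data alone, is whether a longer chain such as 1-aminopentyl would stay with compound 4 or return to the level of compound 1 and compound 2. Also open, as far as these compounds go, is whether a larger ring amine such as piperidin-2-yl would keep the number of compound 3.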